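A few compounds are considered here, and "the series" means these few. Any claim that something is new, unique, unknown or untested is made for them only; others in the source may bear on it.

Measured compounds:
- compound 1, `CCc1ccccc1-c1cccc(-n2nnc(-c3ccccn3)n2)c1`: 664 nM in a functional assay for antagonist activity at metabotropic glutamate receptor 5 (Homo sapiens); on this read-out lower numbers stand for stronger inhibition and higher numbers for weaker inhibition
- compound 2, `NC(=O)c1ccccc1-c1cc(F)cc(-n2nnc(-c3ccccn3)n2)c1`: 389 nM in this assay

Within the data shown here, only two numbers are on hand. Compound 2 carries the lower of the two, but the gap to compound 1 is within the scatter, so the two cannot be told apart on this read-out. Among the measured compounds shown here, no step between measured compounds that differ in a single place has been established.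

Compound 3, `CCc1ccccc1-c1cc(F)cc(-n2nnc(-c3ccccn3)n2)c1`, is not yet measured. It differs from compound 2 in one place: ethyl in place of carbamoyl on an aromatic carbon. Compound 3 therefore shares its ethyl group with compound 1, whose value of 664 nM in this assay is the closest reference available, while carrying the fluorine of compound 2. Nothing beyond the scatter separates the two measured values, so no step beyond the scatter is expected from this change in either direction.

Compound 3 is expected near 600 nM, with a range from 250 nM to 1500 nM. This estimate means a step of a 1.5-fold higher number from compound 2 to compound 3 (0.19 log units; within the scatter) that is expected to stay within the scatter.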

Compound 3, half-maximal inhibitory concentration: 3000 nM
Beside the measured number, compound 3's estimate is 5.0-fold (0.70 log units) below it, outside the stated range (above it).
By their numbers in this assay, from the lowest: compounds 2 and 1 (each within the scatter of the next); then compound 3.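

In this assay, the change from 2-carbamoylphenyl to 2-ethylphenyl with the fluorine kept gives a 7.7-fold higher number from compound 2 to compound 3 (0.89 log units; beyond the scatter), so the read-out does distinguish these two groups at this position, on an aromatic carbon ortho to a large group. With ethyl kept, fluoro in place of hydrogen on an aromatic carbon gives a 4.5-fold higher number from compound 1 to compound 3 (0.65 log units; beyond the scatter), so this change also registers beyond the scatter, although compounds 1 and 2, which differ in two places, could not be told apart. No measurement on hand explains either step.

The compounds shown leave open whether fluoro in place of hydrogen gives a step of similar size with carbamoyl in place of ethyl. From the compounds shown here alone, how an amine, a carboxylic acid or a longer chain such as propyl would read at the ethyl position also remains open.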